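Trifluoromethoxy added to compound 2

A few compounds are considered here, and "the series" means these few. Any claim that something is new, unique, unknown or untested is made for them only; others in the source may bear on it.

In an ADME assay on microsomes from liver (Mus musculus) for metabolic stability, with a stated time of 30 min, tested at 1 uM (on this read-out lower numbers stand for a less stable compound and higher numbers for a more stable compound), compound 2 (`N#C/N=C(\NCc1ccc(S(=O)(=O)c2ccccc2)cc1)Nc1ccncc1`) gives 57% and stands within the scatter of compound 3 (`O=C(NCc1ccc(S(=O)(=O)c2ccccc2)cc1)c1cc2cnccc2[nH]1`) at 54% as its reading. Compound 1 (`N#C/N=C(\NCc1ccc(S(=O)(=O)c2ccccc2)cc1)Nc1cccnc1`) gives 14% as its reading. Within the data shown here, that reading lies under the one of compound 2, and the gap is beyond the scatter. Compound 4 (`N#C/N=C(\NCc1ccc(S(=O)(=O)c2cccc(OC(F)(F)F)c2)cc1)Nc1ccncc1`) carries trifluoromethoxy in place of hydrogen on an aromatic carbon. Among the measured compounds shown here, the one measured step (a number 43 percentage points higher from compound 1 to compound 2 (beyond the scatter)) is large, but it is pyridin-4-yl in place of pyridin-3-yl on an amine nitrogen, a different place. For the measured compounds named here, no measured compound carries a group at the new position, so the expectation is loose. A small fall in this assay, not clearly beyond the scatter, is expected (a number 9 percentage points lower from compound 2 to compound 4 (within the scatter)). Compound 4 is estimated at 48% (range 28% to 68%).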

Compound 4, percent of the compound remaining: 55%
For compound 4 the middle estimate is 7 percentage points below the measured one; low and high end bracket the measured number.
By their numbers in this assay, from the lowest: compound 1; then compounds 3, 4 and 2 (each within the scatter of the next).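

The change from phenyl to 3-(trifluoromethoxy)phenyl gives a number 2 percentage points lower from compound 2 to compound 4 (within the scatter) in this assay, so this aromatic carbon carries trifluoromethoxy without a change beyond the scatter. Among these compounds, the earlier compounds carry no group on this ring, and the only earlier step, a number 43 percentage points higher from compound 1 to compound 2 (beyond the scatter), lies in a different place. Nothing at hand gives a reason for this reading.

Going by these compounds, whether an amine or a carboxylic acid at the same aromatic carbon would read alike stays open. So does whether trifluoromethoxy would behave the same way on compound 1.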